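Chain unsaturation and ring methylation in a chromone series

The source may hold more compounds than are shown below. What is called first, only, known or untested is meant among the compounds shown, and "the series" means these compounds.

Compound 1 `CCCCC/C=C\C/C=C\CCCCCCCc1cc(=O)c2c(O)c(C)c(O)cc2o1`: > 84100 nM
Compound 2 `CCCCCCCCCCCCCCCc1cc(=O)c2c(O)c(C)c(O)c(C)c2o1`: > 67200 nM
Compound 3 `CCCCCCCCCCCCCCCc1cc(=O)c2c(O)c(C)c(O)cc2o1`: 43200 nM

Three compounds were tested in a functional assay on MCF7 cells (Homo sapiens) for antiproliferative activity, read by MTT assay; a lower number here means a stronger inhibitor, a higher number a weaker inhibitor. Compound 3 gives a number, 43200 nM. The value for compound 1 is a limit of the assay, (the limit of > 84100 nM in this assay, at which 1 of the 3 values shown sits). The value for compound 2 is likewise a limit, (the limit of > 67200 nM in this assay, at which 1 of the 3 values shown sits). The change deca-1,4-dien-1-yl in place of octyl on a saturated chain carbon, seven bonds along the chain from an aromatic carbon gives an at least 1.9-fold higher number from compound 3 to compound 1 (0.28 log units; that floor lies within the scatter). The change methyl in place of hydrogen on an aromatic carbon gives an at least 1.5-fold lower number from compound 2 to compound 3 (0.19 log units; that floor lies within the scatter), a step which rests on a limit at one end.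

Compound 4 `CCCCC/C=C\C/C=C\CCCCCCCc1cc(=O)c2c(O)c(C)c(O)c(C)c2o1` has not been measured. It differs from compound 2 by deca-1,4-dien-1-yl in place of octyl on a saturated chain carbon, seven bonds along the chain from an aromatic carbon, the same change that turns compound 3 into compound 1, at a place described in identical words. Compound 2 itself stands only at a limit, > 67200 nM, and the one measured case of this change, an at least 1.9-fold higher number from compound 3 to compound 1 (0.28 log units; that floor lies within the scatter), moved the number upward. The step from compound 2 to compound 4 is therefore expected to be a step that the limit leaves unreadable from compound 2 to compound 4, most likely leaving compound 4 beyond the assay ceiling. Compound 4 is estimated at 120000 nM in this assay.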

Compound 4, half-maximal inhibitory concentration: > 84100 nM
Compound 4: only a limit was reported (the forecaster's own chance of this, stated with the estimate: 85%); the middle value is on the limit's open side.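

In this assay compound 4 gives > 84100 nM, a limit of the assay and not a number. Compound 1 and compound 2 also stand at limits, and neither the step from compound 2 to compound 4 nor the step from compound 1 to compound 4 can be read. The compounds shown leave open how compound 1, compound 2 and compound 4 rank against one another in this assay.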